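The compounds below may be only part of what the source reports. "The series", "measured", "known", "first", "only" and "open" are said of these compounds alone.

Measured compounds:
compound 1 `CCC(C)(C)Cc1c[nH]c(CCc2ccc(-c3ccncc3)cc2)n1` — in a functional assay on HEK293 cells for agonist activity at Bombesin receptor subtype-3 (Homo sapiens), read by luminescence and calcium flux, with a stated time of 10 min (on this read-out higher numbers stand for an effect only at larger amounts of compound and lower numbers for an effect already at smaller amounts), compound 1 gives 305 nM
compound 2 `CCC(C)(C)Cc1c[nH]c(CCc2ccc(-n3ccnn3)cc2)n1` — compound 2 gives 641 nM
compound 3 `CCC(C)(C)Cc1c[nH]c(CCc2ccc(-c3cnsc3)cc2)n1` — compound 3 gives 44 nM

Compound 3 holds the lowest number of the three. Both steps toward it, a 6.9-fold lower number from compound 1 to compound 3 (0.84 log units; beyond the scatter) and a 15-fold lower number from compound 2 to compound 3 (1.16 log units; beyond the scatter), lie beyond the scatter, so compound 3 is the most potent of the measured set in this assay.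

The move to compound 4 `CCC(C)(C)Cc1c[nH]c(CCc2ccc(-n3cncn3)cc2)n1` is 1H-1,2,4-triazol-1-yl in place of 1,2-thiazol-4-yl on an aromatic carbon. The measured step that bears on it most directly is a 15-fold lower number from compound 2 to compound 3 (1.16 log units; beyond the scatter), in which a nitrogen-linked five-membered ring with three hetero atoms gave way to the 1,2-thiazol-4-yl; the change to compound 4 runs the other way, back to a nitrogen-linked ring of the same kind as that of compound 2. Also relevant, though smaller, is a 2.1-fold higher number from compound 1 to compound 2 (0.32 log units; beyond the scatter), showing that a nitrogen-linked triazolyl gave a higher number than pyridin-4-yl as well. Compound 4 is therefore expected to move to a clearly higher number in this assay, largely undoing the gain seen for compound 3; the expected step is a 9.1-fold higher number from compound 3 to compound 4 (0.96 log units; beyond the scatter). The estimate for compound 4 is 400 nM, with a range of 100 nM to 1500 nM.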

Compound 4, half-maximal effective concentration: 570 nM
Beside the measured number, compound 4's estimate is 1.4-fold (0.15 log units) below it; low and high end bracket the measured number.
By their numbers in this assay, from the lowest: compound 3; then compounds 1, 4 and 2 (each within the scatter of the next, the first and the last beyond it).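

In this assay, 1H-1,2,4-triazol-1-yl in place of 1,2-thiazol-4-yl on this aromatic carbon gives a 13-fold higher number from compound 3 to compound 4 (1.11 log units; beyond the scatter). This shows that the large gap between compound 2 and compound 3 is not tied to a single nitrogen-linked triazolyl. The two triazolyl groups cannot be told apart here, with a 1.1-fold lower number from compound 2 to compound 4 (0.05 log units; within the scatter) as their step, so rearranging the ring nitrogens within a nitrogen-linked triazolyl shows no effect beyond the scatter in this pair. The pyridin-4-yl group and the 1H-1,2,4-triazol-1-yl group also fall within the scatter of each other, with a 1.9-fold higher number from compound 1 to compound 4 (0.27 log units; within the scatter) as their step, so the separation of compound 1 from compound 2 does not extend to every nitrogen-linked triazolyl, and among these four groups only the 1,2-thiazol-4-yl stands clearly apart.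

Still open, as far as these compounds go, is whether the low number of compound 3 depends on the ring sulfur or on the carbon-linked five-membered ring, a question that a carbon-linked thiophen-3-yl or 1,2-oxazol-4-yl ring at this place would address. Nothing available here accounts for the gap between the 1,2-thiazol-4-yl and the two triazolyl groups.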